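Three limits and a trifluoroethoxymethyl analogue

A few compounds are considered here, and "the series" means these few. Any claim that something is new, unique, unknown or untested is made for them only; others in the source may bear on it.

Measured in a functional assay on SK-BR-3 cells (Homo sapiens) for cytotoxicity, read by MTT assay, with a stated time of 72 h; on this read-out higher numbers stand for an effect only at larger amounts of compound and lower numbers for an effect already at smaller amounts:
- compound 1, `CCOc1c(-c2occ(C)c2C(=O)O)ccc2c(CC)cccc12`: a limit, > 10 ug/mL
- compound 2, `CCCOC(=O)c1c(C)coc1-c1ccc2c(CC)cccc2c1OC`: a limit, > 10 ug/mL
- compound 3, `CCc1cccc2c(OC(C)=O)c(-c3occ(C)c3COC(C)=O)ccc12`: a limit, > 10 ug/mL

All three values are limits of this assay and not numbers, so compound 2 stands nowhere in particular: it sits at the same limit as compound 1 and compound 3, and no ordering among the three can be drawn. The one firm point in the set is the limit of > 10 ug/mL in this assay, at which 3 of the 3 values shown sit.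

Compound 4, `CCc1cccc2c(OC)c(-c3occ(C)c3COCC(F)(F)F)ccc12`, remains to be measured in this assay. It differs from compound 2 by (2,2,2-trifluoroethoxy)methyl in place of propoxycarbonyl on an aromatic carbon; in words, (2,2,2-trifluoroethoxy)methyl in place of propoxycarbonyl on an aromatic carbon. Among the measured compounds shown here, no measured pair in the set isolates a change of this kind, so there is no step to lean on. Given (the limit of > 10 ug/mL in this assay, at which 3 of the 3 values shown sit), the expected step is a step that the limit leaves unreadable from compound 2 to compound 4, nothing beyond the scatter in either direction. For compound 4 the estimate in this assay is 15 ug/mL, within 5 ug/mL to 40 ug/mL, and the most likely outcome is again only a limit.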

Compound 4, concentration for half-maximal effect: 5.3 ug/mL
Estimate against measurement, compound 4: 2.8-fold (0.45 log units) above; the range from low to high includes it.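

In this assay compound 4 is the only compound shown that gives a number rather than a limit, so a substituent on this aromatic carbon of the five-membered ring can leave the series with a readable value. Placing (2,2,2-trifluoroethoxy)methyl there in place of propoxycarbonyl gives an at least 1.8-fold lower number from compound 2 to compound 4 (0.27 log units; that floor lies within the scatter). Compound 2 has only a limit, so the true size of this step stays unread, and the floor alone does not separate the pair: the limit of > 10 ug/mL in this assay, at which 3 of the 4 values shown sit.

The compounds shown do not tell whether the number for compound 4 follows from the fluorines, the ether oxygen or the loss of the carbonyl. An unfluorinated ethoxymethyl group or an aminomethyl group on the same aromatic carbon would separate these parts of the change.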